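The compounds below may be only part of what the source reports. "The series", "measured", "known", "first", "only" and "open" are said of these compounds alone.

Compound 1 `COc1ccc(N(C)C(=O)N(C)c2cc(OC)c(OC)c(OC)c2)cc1` and compound 2 `COc1cc(N(C)C(=O)N(C)c2ccc(F)cc2)cc(OC)c1OC` share one core; the difference between that core and the core of compound 3 `COc1ccc(NC(=O)Nc2cc(OC)c(OC)c(OC)c2)cc1` is not broken down here. In a functional assay on ONS-76 cells (Homo sapiens) for cytotoxicity, read by MTT assay, with a stated time of 72 h (a lower number here means a stronger inhibitor, a higher number a weaker inhibitor), compound 1 returns a limit of the assay, >= 125000 nM. Compound 2 likewise returns a limit of the assay, >= 125000 nM. The two limits leave a step that the two limits leave unreadable from compound 1 to compound 2 without readable size, as shown by the limit of >= 125000 nM in this assay, at which 2 of the 3 values shown sit. In this assay, among the compounds with values here, compound 3 gives 12900 nM, the only number among the three. Compound 4 `COc1cc(NC(=O)Nc2ccc(F)cc2)cc(OC)c1OC` carries the change (fluoro in place of methoxy on an aromatic carbon), which is the same as fluoro in place of methoxy on an aromatic carbon, at the same place. Because a step that the two limits leave unreadable from compound 1 to compound 2 gives no size, the expected shift a 1.6-fold higher number from compound 3 to compound 4 (0.19 log units; within the scatter) is set near neutral with wide bounds. Compound 4 is expected at 20000 nM, between 5000 nM and 90000 nM.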

Compound 4, half-maximal inhibitory concentration: 63300 nM
For compound 4 the middle estimate is 3.2-fold (0.50 log units) below the measured one; measured number inside the range.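

In this assay, replacing 4-methoxyphenyl with 4-fluorophenyl on the core of compound 3 gives a 4.9-fold higher number from compound 3 to compound 4 (0.69 log units; beyond the scatter). This is one modest step on one core and sets no rule for the series. The same change on the core of compound 1 cannot be read, so nothing shows whether the size of the step carries over from one core to the other: the limit of >= 125000 nM in this assay, at which 2 of the 4 values shown sit.

Open, from the compounds shown here alone, is how an amine or a carboxylic acid at this place on the core of compound 3 would compare with methoxy and fluoro. Also open, going by these compounds, is whether any change to the core of compound 1 would give a number rather than a limit.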